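From Nitro to Iodo on a Shared Core

This account rests on a few compounds, and the source may have more. Where it says the series, first, only, none or still open, it means among the compounds named here.

Measured compounds:
- compound 1: `O=c1cc(-c2ccccc2)oc2cc(OCCCCNc3nc4ccc([N+](=O)[O-])cc4s3)cc(O)c12`, giving 30.3 ug/mL in a physicochemical assay, read by spectrophotometry, with a stated time of 25 min; on this read-out lower numbers stand for stronger inhibition and higher numbers for weaker inhibition
- compound 2: `O=c1cc(-c2ccccc2)oc2cc(OCCCCNc3nc4ccc(Br)cc4s3)cc(O)c12`, giving 16.1 ug/mL in this assay

Of the two numbers in hand, compound 1 gives the highest; its nearest neighbour is compound 2, and the step of a 1.9-fold lower number from compound 1 to compound 2 (0.27 log units; within the scatter) is within the scatter. Compound 3 is `O=c1cc(-c2ccccc2)oc2cc(OCCCCNc3nc4ccc(I)cc4s3)cc(O)c12` and has not yet been measured. It differs from compound 1 in one place: iodo in place of nitro on an aromatic carbon. Among the compounds with values here, the only measured step that bears on this change is the one from compound 1 to compound 2, where the same nitro group made way for bromo at the same position and the number moved only within the scatter. Iodo is expected to behave much as bromo did, so the step from compound 1 to compound 3 is expected to be small, pointing to a lower number if anywhere, but not clearly beyond the scatter. Compound 3 is therefore estimated at 16 ug/mL, with a range from 7 ug/mL to 36 ug/mL, which means an expected step of a 1.9-fold lower number from compound 1 to compound 3 (0.28 log units; within the scatter).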

Compound 3, half-maximal inhibitory concentration: 25.4 ug/mL
Beside the measured number, compound 3's estimate is 1.6-fold (0.20 log units) below it; low and high end bracket the measured number.
By their numbers in this assay, from the lowest: compounds 2, 3 and 1 (each within the scatter of the next).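

With iodo at this place, the step from nitro reads as a 1.2-fold lower number from compound 1 to compound 3 (0.08 log units; within the scatter) in this assay and the step from bromo reads as a 1.6-fold higher number from compound 2 to compound 3 (0.20 log units; within the scatter) on the same read-out. Within the data shown here, compound 3 thus adds a second halogen to the comparison, and neither of its steps separates it from the earlier compounds, so nitro, bromo and iodo on this aromatic carbon all lie within the scatter of one another, and no compound among the three stands apart. The exchange of a three-atom group bearing two hydrogen-bond acceptors for a single iodine atom with none leaves the number within the scatter, which the bromo step alone could only suggest for one halogen, and nothing at hand offers any explanation of this sameness.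

What the three compounds leave open is whether a plain hydrogen, an amine or a carboxylic acid at this place would give a step beyond the scatter. They also leave open whether a longer chain elsewhere on the shared core would alter the picture, and whether these groups would still read alike on any other read-out.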